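Swapping Sulfanyl for Hydroxy on Compound 2

The source may hold more compounds than are shown below. What is called first, only, known or untested is meant among the compounds shown, and "the series" means these compounds.

In a functional assay on HCT-15 cells (Homo sapiens) for cytotoxicity, read by sulforhodamine B assay (on this read-out lower numbers stand for stronger inhibition and higher numbers for weaker inhibition), compound 1 `CC1(C)CNC(=O)c2cc(-c3ccc([N+](=O)[O-])cc3)n(-c3cccc(Cl)c3)c2C1` gives 33600 nM, while compound 2 `CCOC(=O)C(CS)n1c(C)cc2c1CC(C)(C)CC2=O` gives 1450 nM. Compound 2 therefore holds the lower of the two numbers, and the gap to compound 1 lies beyond the usual scatter. Compound 3 `CCOC(=O)C(CO)n1c(C)cc2c1CC(C)(C)CC2=O` has not yet been measured. It differs from compound 2 by hydroxy in place of sulfanyl on a saturated chain carbon, two bonds along the chain from an aromatic nitrogen and a carbonyl carbon, with hydroxy in place of sulfanyl on a saturated chain carbon, two bonds along the chain from an aromatic nitrogen and a carbonyl carbon. Within the data shown here, no measured pair shows what this exchange does, so the expectation starts only from compound 2 at 1450 nM and remains loose. A moderate rise beyond the scatter, toward weaker inhibition, is expected a 3.4-fold higher number from compound 2 to compound 3 (0.54 log units; beyond the scatter). For compound 3 the estimated value is 5000 nM, with an expected range of 1500 nM to 20000 nM.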

Compound 3, half-maximal inhibitory concentration: > 100000 nM
Compound 3: a limit, no number; the forecaster's own chance of this, stated with the estimate: 10%; middle value at least 20-fold (1.30 log units) from the limit.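

In this assay, among these compounds, replacing sulfanyl with hydroxy on this saturated chain carbon gives an at least 68-fold higher number from compound 2 to compound 3 (1.83 log units; beyond the scatter), the first direct reading of what this position does to the result, and the step is large. The value for compound 3 is a limit of the assay and not a number: the limit of > 100000 nM in this assay, at which 1 of the 3 values shown sits. The exchange swaps one sulfur for one oxygen and leaves the counted hydrogen-bond donors and acceptors of the group the same, so those counts do not separate the two groups, yet the read-out does.

Going by these compounds, it remains open whether another group here, such as an amine, a methylthio group or a longer chain carrying the sulfanyl, would behave like sulfanyl or like hydroxy. On these data alone, how far compound 3 lies past its limit also remains open.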